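This account rests on a few compounds, and the source may have more. Where it says the series, first, only, none or still open, it means among the compounds named here.

Within the data shown here, compound 2 `Cc1cc(Nc2ccccc2)c(S(C)(=O)=O)cc1C(=O)N=C(N)N` is one of two compounds measured in a functional assay for inhibition of sodium/hydrogen exchanger (Oryctolagus cuniculus) (a lower number here means a stronger inhibitor, a higher number a weaker inhibitor), and there compound 2 gives 21 nM. Among the measured compounds shown here, compound 1 `COc1cc(C)c(C(=O)N=C(N)N)cc1S(C)(=O)=O` gives 16 nM in this assay, and the single change between the two, a 1.3-fold higher number from compound 1 to compound 2 (0.12 log units; within the scatter), stays within the scatter, so the two numbers cannot be told apart. Compound 3 `Cc1cc(Oc2cncc(Cl)c2)c(S(C)(=O)=O)cc1C(=O)N=C(N)N` has not been measured. It differs from compound 2 by (5-chloropyridin-3-yl)oxy in place of anilino on an aromatic carbon. For the measured compounds named here, the only measured step that bears on this position is a 1.3-fold higher number from compound 1 to compound 2 (0.12 log units; within the scatter), which swapped one group for another at the same aromatic carbon and moved the number by no more than the scatter. On that basis no change beyond the scatter is expected here, in either direction. Compound 3 is therefore estimated to give 25 nM in this assay, within a range of 8 nM to 80 nM, which is expected to amount to a 1.2-fold higher number from compound 2 to compound 3 (0.08 log units; within the scatter).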

Compound 3, half-maximal inhibitory concentration: 14 nM
The estimate for compound 3 lay 1.8-fold (0.25 log units) above the measured number, and the stated range covers the measured number.
By their numbers in this assay, from the lowest: compounds 3, 1 and 2 (each within the scatter of the next).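

In this assay, the larger (5-chloropyridin-3-yl)oxy group replaces anilino with a 1.5-fold lower number from compound 2 to compound 3 (0.18 log units; within the scatter), and extending methoxy to this group on the same oxygen gives a 1.1-fold lower number from compound 1 to compound 3 (0.06 log units; within the scatter). This aromatic carbon, ortho to a methylsulfonyl group, therefore carries three quite different groups with no change that can be told from the scatter, even though the anilino hydrogen-bond donor is absent from compound 1 and compound 3 alike and compound 3 adds a ring hetero atom and a chlorine. Nothing available explains why these groups are tolerated equally.

As far as these compounds go, whether this tolerance extends to a carboxylic acid or a simple amine such as dimethylamino at this carbon remains open. So does whether the chlorine or the ring nitrogen of compound 3 matters on its own.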